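Benzylamino in place of piperidin-1-yl on the shared core

The source may hold more compounds than are shown below. What is called first, only, known or untested is meant among the compounds shown, and "the series" means these compounds.

In a functional assay on ECa-109 cells for inhibition, with ECa-109 cell line (Homo sapiens) as the target, read by sulforhodamine B assay (a lower number here means a stronger inhibitor, a higher number a weaker inhibitor), compound 1 `O=C1C(Nc2ccccc2F)=CC(=O)c2c1nc1n2[C@H]2OC[C@@H](O)[C@H]2OC1` gives 2660 nM and compound 2 `O=C1C(Nc2ccccc2)=CC(=O)c2c1nc1n2[C@H]2OC[C@@H](O)[C@H]2OC1` gives 3560 nM, a pair separated by a 1.3-fold higher number from compound 1 to compound 2 (0.13 log units; within the scatter).

Compound 3 `O=C1C(N2CCCCC2)=CC(=O)c2c1nc1n2[C@H]2OC[C@@H](O)[C@H]2OC1` gives > 8000 nM, which is a limit of the assay and not a number.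

Compound 4 `O=C1C(NCc2ccccc2)=CC(=O)c2c1nc1n2[C@H]2OC[C@@H](O)[C@H]2OC1` is still unmeasured and differs from compound 3 as follows: benzylamino in place of piperidin-1-yl on a double-bonded ring carbon. Like the anilino of compound 2, the entering benzylamino carries a six-membered aromatic ring of carbon only.

Within the data shown here, two measured steps bear on this change: an at least 2.2-fold higher number from compound 2 to compound 3 (0.35 log units; beyond the scatter) and an at least 3.0-fold higher number from compound 1 to compound 3 (0.47 log units; beyond the scatter). Both have piperidin-1-yl entering, so the present change runs the opposite way. Benzylamino is not anilino, however, so only part of that gap is expected to be recovered. A modest move towards a lower number in this assay is therefore expected, and the expected step is an at least 1.7-fold lower number from compound 3 to compound 4 (0.24 log units; that floor lies within the scatter).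

For compound 4 the estimated value is 4500 nM, with an expected range of 1800 nM to 8000 nM.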

Compound 4, half-maximal inhibitory concentration: > 8000 nM
Compound 4 ended at the assay's limit; the forecaster's own chance of this, stated with the estimate: 25%; middle value at least 1.7-fold (0.24 log units) away from the limit.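

In this assay compound 4 gives > 8000 nM, which is a limit of the assay and not a number. Benzyl in place of phenyl on the amine nitrogen gives an at least 2.2-fold higher number from compound 2 to compound 4 (0.35 log units; beyond the scatter), and benzyl in place of 2-fluorophenyl gives an at least 3.0-fold higher number from compound 1 to compound 4 (0.47 log units; beyond the scatter), so a hydrogen-bond donor and a six-membered aromatic ring of carbon only, both present in benzylamino, do not together keep compound 4 level with the anilino compounds at this double-bonded ring carbon. The step between compound 3 and compound 4 cannot be read because both sit at the limit: the limit of > 8000 nM in this assay, at which 2 of the 4 values shown sit.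

Going by these compounds, the true values of compound 3 and compound 4 stay open, so piperidin-1-yl and benzylamino cannot be ordered. Also open, on these data alone, is how a chloro or methoxy group on the anilino ring would read against compound 1 and compound 2.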